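The compounds below may be only part of what the source reports. "The series", "measured", "known", "first", "only" and "open" are said of these compounds alone.

Measured compounds:
compound 1 `COc1ccc(F)cc1CNCCCNc1ccnc2cc(C3CCCCC3)ccc12`: 9.47
compound 2 `COc1ccc(F)cc1CNCCCNc1ccnc2cc(Cc3cccc(C(F)(F)F)c3)ccc12`: 9.47
compound 3 `COc1ccc(F)cc1CNCCCNc1ccnc2cc(-c3cccc4ccccc34)ccc12`: 9.47

In a physicochemical assay for acid dissociation, compound 1 gives 9.47. Compounds 2 and 3 sit level with it: the steps of no change at the digits printed from compound 1 to compound 2 (within the scatter) and no change at the digits printed from compound 1 to compound 3 (within the scatter) are within the scatter, as is no change at the digits printed from compound 2 to compound 3 (within the scatter). Compound 1 therefore stands neither apart from nor ordered against the other two.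

Compound 4 `c1coc(CNCCCNc2ccnc3cc(C4CCCCC4)ccc23)c1` is not yet measured in this assay. It differs from compound 1 as follows: furan-2-yl in place of 5-fluoro-2-methoxyphenyl on a saturated chain carbon bound to an amine nitrogen. Cut one bond further out, the same difference reads 5-fluoro-2-methoxybenzyl to (furan-2-yl)methyl.

For the measured compounds named here, none of the measured steps touches this place. All three exchange the group on an aromatic carbon of the shared core, and each read as no change; they show the acid dissociation constant insensitive to that position, but give no direct guide for an exchange on a saturated chain carbon bound to an amine nitrogen. Going by the values given here, no step of this kind has been measured, so the expectation rests on compound 1 alone, with a widened range. From compound 1 a step of a number 0.17 log units lower from compound 1 to compound 4 (within the scatter) is expected. Compound 4 is thus estimated at 9.3, between 8.6 and 9.9.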

Compound 4, acid dissociation constant: 9.47
Compound 4: the middle estimate sits 0.17 log units below what was measured; low and high end bracket the measured number.
By their numbers in this assay, from the lowest: compounds 1, 2, 3 and 4 (each within the scatter of the next).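

In this assay, furan-2-yl in place of 5-fluoro-2-methoxyphenyl on a saturated chain carbon bound to an amine nitrogen gives no change at the digits printed from compound 1 to compound 4 (within the scatter), the only reading at this place among the compounds shown. The earlier steps shown here covered only exchanges on an aromatic carbon of the shared core, whereas this one shows that the read-out can also hold level at a second place, even as a six-membered aromatic ring of carbon only gives way to a five-membered aromatic ring with 1 hetero atom and the fluorine and methoxy substituents leave. No measurement in hand offers an explanation for this result.

From the compounds shown here alone, with only aromatic rings tested at this place, it remains open whether the read-out would also hold with a piperidine ring, a primary amine or a carboxylic acid there, or with a longer chain carrying the amine nitrogens. Going by these compounds, it also remains open whether furan-2-yl would read the same alongside naphthalen-1-yl or 3-(trifluoromethyl)benzyl on the aromatic carbon of the shared core.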